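This account rests on a few compounds, and the source may have more. Where it says the series, first, only, none or still open, it means among the compounds named here.

Measured so far in a functional assay on the whole organism (strain Kunming) with Mus musculus as the target, with a stated time of 0.5 h, at a dose of 300 mg/kg by the intraperitoneal route; a lower number here means a stronger effect, a higher number a weaker effect of the compound at the dose given:
- compound 1, `COc1cc(OC)c(OC)cc1/C=C/COC(=O)/C=C/c1ccccc1C(F)(F)F`: 75%
- compound 2, `COc1cc(OC)c(OC)cc1/C=C/COC(=O)/C=C/c1ccc(F)cc1`: 75%

Compound 2 stands level with compound 1 at the digits shown; the single step recorded, no change at the digits printed from compound 1 to compound 2 (within the scatter), is within the scatter, so this assay has so far not separated the two aryl groups tested on the double-bonded chain carbon.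

Compound 3, `COc1cccc(/C=C/C(=O)OC/C=C/c2cc(OC)c(OC)cc2OC)c1`, is not yet measured. It differs from compound 2 in one place: 3-methoxyphenyl in place of 4-fluorophenyl on a double-bonded chain carbon bound to a double-bonded chain carbon.

Within the data shown here, the only step that bears on this change is the aryl swap from compound 1 to compound 2, and it was flat. With no evidence of movement in this assay from one substituted phenyl to another, the expected step of a number 2 percentage points lower from compound 2 to compound 3 (within the scatter) is none beyond the scatter, and compound 3 is estimated at 73% in this assay, with a range from 50% to 92%.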

Compound 3, a percentage reported as activity, at one dose (the size of the read-out at that dose, not a potency): 75%
Estimate against measurement, compound 3: 2 percentage points below, and the stated range covers the measured number.
By their numbers in this assay, from the lowest: compounds 1, 2 and 3 (each within the scatter of the next).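

In this assay, 3-methoxyphenyl in place of 4-fluorophenyl on a double-bonded chain carbon bound to a double-bonded chain carbon gives no change at the digits printed from compound 2 to compound 3 (within the scatter), and 3-methoxyphenyl in place of 2-(trifluoromethyl)phenyl gives no change at the digits printed from compound 1 to compound 3 (within the scatter). The position now carries three differently substituted phenyl groups that this assay does not separate, and the change from 4-fluorophenyl to 3-methoxyphenyl, which adds a hydrogen-bond acceptor by the count, does not separate them either. Nothing available here accounts for this flat reading.

Still open, going by these compounds, is whether the read-out moves with a group of another kind at this position, such as a phenyl ring bearing an amine or a carboxylic acid. On these data alone, all three compounds are read at one dose, so whether one would show a stronger or weaker effect than another at a different dose also remains open.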